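The source may report more compounds than this note shows. Statements on the series, on what has been measured and on what is new or still open speak of the compounds shown alone.

Series notes. Compound 1 `Cc1ccc(S(=O)(=O)n2cc(/C=N\c3ccc(N4CCOCC4=O)cc3)c3ccccc32)cc1` and compound 2 `O=C1COCCN1c1ccc(/N=C\c2cn(C(=O)c3ccc(Cl)cc3)c3ccccc23)cc1` differ only in the group on the aromatic nitrogen. In a functional assay on BV-2 cells (Mus musculus) for inhibition, read by ELISA, tested at 10 uM (a higher number here means a weaker effect of the compound at the concentration tested, a lower number a stronger effect), compound 1 gives 101%, and compound 2 gives 76.5%. Among the compounds with values here, the single measured step in the set is a number 24.5 percentage points lower from compound 1 to compound 2 (beyond the scatter). Within the data shown here, on these two numbers compound 2 stands lowest, with compound 1 as its only neighbour at a distance beyond the scatter.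

Compound 3 `O=C1COCCN1c1ccc(/N=C\c2cn(Cc3ccccc3)c3ccccc23)cc1` is not yet measured. It differs from compound 2 by benzyl in place of (4-chlorophenyl)carbonyl on an aromatic nitrogen. Among the measured compounds shown here, no measured pair exchanges the group on the aromatic nitrogen for benzyl, so the only step that bears on this position is the one from compound 1 to compound 2, which moved this assay by a modest amount when (4-chlorophenyl)carbonyl stood in for (4-methylphenyl)sulfonyl. That step shows the position can shift the read-out, but it gives no direction for benzyl in place of (4-chlorophenyl)carbonyl. The expected step is therefore a number 5.5 percentage points higher from compound 2 to compound 3 (within the scatter), an uncertain move that may stay within the scatter or run somewhat higher. Compound 3 is estimated at 82%, within 58% to 105%.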

Compound 3, a percentage reported as activity, at one concentration (the size of the read-out at that concentration, not a potency): 266%
Compound 3: middle estimate off by 184 percentage points, on the low side, and the stated range ends below it.
By their numbers in this assay, from the lowest: compound 2; then compound 1; then compound 3.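

In this assay, within the data shown here, the group on the aromatic nitrogen carries far more of the read-out than the first exchange at this position showed: benzyl in place of (4-chlorophenyl)carbonyl gives a number 189.5 percentage points higher from compound 2 to compound 3 (beyond the scatter), and benzyl in place of (4-methylphenyl)sulfonyl gives a number 165 percentage points higher from compound 1 to compound 3 (beyond the scatter). Both steps are large, run toward a weaker effect at the concentration tested, and put compound 3 at the weak end of the three, so the position can move the read-out upward as well as downward. Of the three groups, benzyl alone has no carbonyl or sulfonyl attached to the ring nitrogen, but nothing in hand accounts for the size of these steps.

The compounds shown do not separate the contribution of the linking carbonyl or sulfonyl from that of the substituent on the phenyl ring, since each group differs from the others in more than one feature. A 4-chlorobenzyl group, an unsubstituted benzoyl group or a short alkyl chain such as ethyl on the same nitrogen would bear on that question.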